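Swapping the Group on the Aromatic Nitrogen

The source may hold more compounds than are shown below. What is called first, only, known or untested is meant among the compounds shown, and "the series" means these compounds.

Of the compounds shown here, three that share one core have been measured in a functional assay on CHO cells for antagonist activity at growth hormone secretagogue receptor type 1 (Homo sapiens); on this read-out higher numbers stand for weaker inhibition and lower numbers for stronger inhibition. Compound 1 `COc1ccc(Cn2c(CCc3ccccc3)nnc2[C@H](NC(=O)C(C)(C)N)c2c[nH]c3ccccc23)cc1` gives 5 nM in this assay. Compound 2 `COc1ccc(Cn2c(CCc3ccccc3)nnc2[C@H](NC(=O)c2ccccn2)c2c[nH]c3ccccc23)c(OC)c1` differs from compound 1 in both the amide and the benzyl group. In this assay compound 2 gives 25 nM. Compound 3 `COc1ccc(-n2c(CCc3ccccc3)nnc2[C@H](NC(=O)c2ccccn2)c2c[nH]c3ccccc23)c(OC)c1` gives 65 nM in this assay, the highest of the three numbers; the nearest is compound 2 and the furthest is compound 1.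

Going by the values given here, the only step between neighbours differing in one place is a 2.6-fold higher number from compound 2 to compound 3 (0.41 log units; beyond the scatter), a 2,4-dimethoxyphenyl in place of a 2,4-dimethoxybenzyl on an aromatic nitrogen. Compound 4 `CCc1ccc(Cn2c(CCc3ccccc3)nnc2[C@H](NC(=O)c2ccccn2)c2c[nH]c3ccccc23)cc1` has not yet been measured; it differs from compound 3 in that (4-ethylbenzyl in place of 2,4-dimethoxyphenyl on an aromatic nitrogen). Among the compounds with values here, the change restores a benzyl group on the aromatic nitrogen, the arrangement found in compound 2, while exchanging the two methoxy groups for a single ethyl group, for which no measured pair gives guidance. The step from compound 2 to compound 3 therefore bears on it in reverse, and compound 1, whose number is the lowest, offers only loose support since its amide also differs. For compound 4 a step of a 3.3-fold lower number from compound 3 to compound 4 (0.51 log units; beyond the scatter) in this assay is expected, toward a lower number. Compound 4 is thus estimated at 20 nM, with a range from 6 nM to 70 nM.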

Compound 4, antagonist equilibrium constant: 513 nM
Beside the measured number, compound 4's estimate is 26-fold (1.41 log units) below it; the whole stated range lies below it.
By their numbers in this assay, from the lowest: compound 1; then compound 2; then compound 3; then compound 4.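

The new number shows that a benzyl group on the aromatic nitrogen does not by itself give a low number in this assay: restoring that link while exchanging the ring substituents brings a 7.9-fold higher number from compound 3 to compound 4 (0.90 log units; beyond the scatter), rather than the lower number that reversing the earlier change might have suggested. With the benzyl link and the amide held constant, the change from 2,4-dimethoxy to 4-ethyl on the ring gives a 21-fold higher number from compound 2 to compound 4 (1.31 log units; beyond the scatter), which is printed as large, whereas replacing 2,4-dimethoxybenzyl with 2,4-dimethoxyphenyl gives the modest 2.6-fold higher number from compound 2 to compound 3 (0.41 log units; beyond the scatter), so among these compounds the ring substituents matter more than the link. Nothing available explains why this position responds in this way.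

The compounds shown leave open whether the higher number of compound 4 comes from losing the two methoxy groups or from adding the ethyl group, since both changes occur in one step. An unsubstituted benzyl group, or a benzyl group with one methoxy group, alongside the amide of compound 2 would separate these two changes, while 4-ethylphenyl on the aromatic nitrogen would test whether the link matters in the same way with an ethyl group on the ring.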